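This account rests on a few compounds, and the source may have more. Where it says the series, first, only, none or still open, it means among the compounds named here.

Values measured in a functional assay on K562 cells (Homo sapiens), read by MTT assay, with a stated time of 72 h; a lower number here means a stronger inhibitor, a higher number a weaker inhibitor:
- Compound 1 `CNc1ncnc2c1c(-c1ccccc1)cn2[C@@H]1O[C@H](CO)[C@@H](O)[C@H]1O`: > 20000 nM, a limit
- Compound 2 `CNc1ncnc2c1c(-c1cc3ccccc3o1)cn2[C@@H]1O[C@H](CO)[C@@H](O)[C@H]1O`: > 20000 nM, a limit
- Compound 3 `C#Cc1cn([C@@H]2O[C@H](CO)[C@@H](O)[C@H]2O)c2ncnc(NC)c12`: 1380 nM

Compound 3 is the only one of the three with an actual number. Compounds 1 and 2 give no number, only (the limit of > 20000 nM in this assay, at which 2 of the 3 values shown sit). Even so, the limits show that compound 3 stands well ahead of both, with an at least 14-fold lower number from compound 1 to compound 3 (1.16 log units; beyond the scatter) and an at least 14-fold lower number from compound 2 to compound 3 (1.16 log units; beyond the scatter), each beyond the scatter.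

The next compound is compound 4 `CNc1ncnc2c1c(I)cn2[C@@H]1O[C@H](CO)[C@@H](O)[C@H]1O`, with iodo in place of ethynyl on an aromatic carbon. For the measured compounds named here, no measured step involves iodo directly. The two steps to compound 3 show only that this carbon is sensitive to what it carries, and that the ring-bearing groups there fare far worse than ethynyl. Iodo, like ethynyl, brings no ring, so a collapse of that size seems unlikely, though a loss remains plausible. The expected change is modest, a 2.9-fold higher number from compound 3 to compound 4 (0.46 log units; beyond the scatter), toward a higher number. For compound 4 the estimated value is 4000 nM, with an expected range from 700 nM to 18000 nM.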

Compound 4, half-maximal inhibitory concentration: > 20000 nM
Compound 4 ended at the assay's limit (the forecaster's own chance of this, stated with the estimate: 25%); middle value at least 5.0-fold (0.69 log units) from the limit.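

Iodo in place of ethynyl gives an at least 14-fold higher number from compound 3 to compound 4 (1.16 log units; beyond the scatter). Until now, only the ring-bearing groups, phenyl and 1-benzofuran-2-yl, had been seen to end at a limit at this aromatic carbon, but iodo brings no ring and a single heavy atom, so a ring is not needed for this large a loss, and ethynyl remains the only group shown here with an actual number in this assay. Compounds 1, 2 and 4 give limits rather than numbers, so the steps among them cannot be read and the three groups cannot be ranked: the limit of > 20000 nM in this assay, at which 3 of the 4 values shown sit.

On these data alone, whether a nitrile, a methyl or a propynyl group on this carbon would give a number or end at the same limit stays open. Also open, as far as these compounds go, is whether a longer chain ending in a triple bond would keep a number in this assay.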